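The source may report more compounds than this note shows. Statements on the series, on what has been measured and on what is new or still open speak of the compounds shown alone.

In a functional assay on HeLa cells (Homo sapiens) for antiproliferative activity, read by MTT assay, with a stated time of 72 h (on this read-out lower numbers stand for stronger inhibition and higher numbers for weaker inhibition), compound 1 (`O=C1COc2ccc(-c3cnc4ccccc4c3)cc2N1C1CCCCC1`) gives 19700 nM. Compound 2 (`O=C1COc2ccc(-c3cccc(NS(=O)(=O)c4ccc(F)cc4)c3)cc2N1c1ccccc1`) gives 17700 nM, which is level with compound 1 within the scatter. Compound 3 (`COc1ncc(-c2ccc3c(c2)N(C2CC2)C(=O)CO3)cc1NS(=O)(=O)c1ccc(F)cc1`) gives 6030 nM, a number clearly lower than either, so compound 1 shares the high end of this small set with compound 2.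

The unmeasured compound 4 (`COc1ccc(N2C(=O)COc3ccc(-c4cnc5ccccc5c4)cc32)cc1`) keeps the core of compound 1 and has 4-methoxyphenyl in place of cyclohexyl on an amide-type nitrogen in a ring. Among the measured compounds shown here, no two measured compounds differ in one place only, so the data give no direct measure of this swap. The nearest hint is compound 2, which also has a six-membered aromatic ring of carbon only on that nitrogen, though it differs elsewhere too, and it gives 17700 nM. A step beyond the scatter is therefore not expected in either direction. The estimate amounts to an expected 1.3-fold lower number from compound 1 to compound 4 (0.12 log units; within the scatter). The estimated value for compound 4 is 15000 nM, with an expected range of 6000 nM to 40000 nM.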

Compound 4, half-maximal inhibitory concentration: > 40000 nM
Compound 4 was reported as a limit; the forecaster's own chance of this, stated with the estimate: 15%; middle value at least 2.6-fold (0.42 log units) from the limit.
By their numbers in this assay, from the lowest: compound 3; then compounds 2 and 1 (each within the scatter of the next). At a limit, above all of these: compound 4.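

Among the compounds shown here, with the core of compound 1 held fixed, this pair gives the first direct reading at the amide-type nitrogen in a ring, and in this assay the change to 4-methoxyphenyl from cyclohexyl is an at least 2.0-fold higher number from compound 1 to compound 4 (0.30 log units; that floor lies within the scatter). Compound 4 stands at a limit of the assay, which is not a number: the limit of > 40000 nM in this assay, at which 1 of the 4 values shown sits. The printed floor of the step lies within the scatter, so the pair sets only a lower bound on the change, but it shows no gain in inhibition from this swap.

From the compounds shown here alone, how this nitrogen responds to a small methyl group or a longer chain such as butyl, on the same core, remains open. Also open, going by these compounds, is whether a hydroxyl group in place of the methoxy group would give a readable number rather than a limit.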